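Swapping a ring for a chain at the hydroxamic acid end

The source may hold more compounds than are shown below. What is called first, only, known or untested is meant among the compounds shown, and "the series" means these compounds.

Compound 1 `CCOc1cc(C(C)(C)C)ccc1C1=NC(c2ccc(Cl)cc2)C(c2ccc(Cl)cc2)N1C(=O)N1CCN(Cc2ccc(C(=O)NO)cc2)CC1`: in an assay on isolated protein for inhibition of E3 ubiquitin-protein ligase Mdm2 (Homo sapiens), read by fluorescence polarization, with a stated time of 30 min (a lower number here means a stronger inhibitor, a higher number a weaker inhibitor), compound 1 gives 260 nM.
Compound 2 `CCOc1cc(C(C)(C)C)ccc1C1=NC(c2ccc(Cl)cc2)C(c2ccc(Cl)cc2)N1C(=O)NCCCCC(=O)Nc1ccccc1N`: in this assay compound 2 gives 960 nM.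

Of these two numbers compound 1 holds the lower one, and compound 2 sits above it by more than the usual scatter. Compound 3 `CCOc1cc(C(C)(C)C)ccc1C1=NC(c2ccc(Cl)cc2)C(c2ccc(Cl)cc2)N1C(=O)N1CCN(CCCCCCCC(=O)NO)CC1` has not been measured. It differs from compound 1 in one place: 6-(hydroxycarbamoyl)hexyl in place of 4-(hydroxycarbamoyl)phenyl on a saturated chain carbon bound to an amine nitrogen in a ring. The group that leaves has one aromatic ring, the group that enters has no ring, and both carry the same donors and acceptors, while the shared core is untouched. In this assay a step no larger than the usual scatter is therefore expected, in either direction. Compound 3 is expected to give 350 nM, with a range from 120 nM to 1000 nM. This expected value for compound 3 means a step of a 1.3-fold higher number from compound 1 to compound 3 (0.13 log units; within the scatter).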

Compound 3, inhibition constant: 290 nM
Compound 3: the middle estimate sits 1.2-fold (0.08 log units) above what was measured; the range from low to high includes it.
By their numbers in this assay, from the lowest: compounds 1 and 3 (each within the scatter of the next); then compound 2.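

In this assay, 6-(hydroxycarbamoyl)hexyl in place of 4-(hydroxycarbamoyl)phenyl gives a 1.1-fold higher number from compound 1 to compound 3 (0.05 log units; within the scatter). At this place, on a saturated chain carbon bound to an amine nitrogen in a ring, a group with one aromatic ring and a group with no ring therefore read alike within the scatter, something the earlier pair, differing in more than one place, could not show. No measurement shown explains this likeness. Still open, as far as these compounds go, is how a shorter chain ending in hydroxycarbamoyl, or a carboxylic acid at the chain end, would read.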